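Swapping One Fluoro-Methylphenyl Group for Another

A few compounds are considered here, and "the series" means these few. Any claim that something is new, unique, unknown or untested is made for them only; others in the source may bear on it.

In a functional assay on RPMI-8226 cells (Homo sapiens) for antiproliferative activity, read by radiometric assay, with a stated time of 72 h (a lower number here means a stronger inhibitor, a higher number a weaker inhibitor), compound 1 `Cc1ccccc1Nc1ncnc2cc(NC(=O)CCCCCCC(=O)NO)sc12` gives 1750 nM and compound 2 `Cc1cc(F)ccc1Nc1ncnc2cc(NC(=O)CCCCCCC(=O)NO)sc12` gives 1950 nM, so compound 2 stands level with compound 1 within the scatter. Compound 3 `Cc1ccc(F)c(Nc2ncnc3cc(NC(=O)CCCCCCC(=O)NO)sc23)c1` has the same atoms as compound 2, joined differently: 2-fluoro-5-methylphenyl in place of 4-fluoro-2-methylphenyl on a nitrogen on an aromatic ring. Among the compounds with values here, the one measured step, fluoro in place of hydrogen on an aromatic carbon, is small: a 1.1-fold higher number from compound 1 to compound 2 (0.05 log units; within the scatter). Within the data shown here, no measured step changes where the methyl sits, so the guide is weak. The expected result is no clear shift in either direction, with an estimated 1.0-fold lower number from compound 2 to compound 3 (0.01 log units; within the scatter). The estimate for compound 3 is 1900 nM, with an expected range of 800 nM to 4500 nM.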

Compound 3, half-maximal inhibitory concentration: 1060 nM
For compound 3 the middle estimate is 1.8-fold (0.25 log units) above the measured one, and the stated range covers the measured number.
By their numbers in this assay, from the lowest: compounds 3, 1 and 2 (each within the scatter of the next).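

In this assay the swap of 4-fluoro-2-methylphenyl for 2-fluoro-5-methylphenyl on the nitrogen gives a 1.8-fold lower number from compound 2 to compound 3 (0.26 log units; within the scatter) and the swap of 2-methylphenyl for 2-fluoro-5-methylphenyl gives a 1.7-fold lower number from compound 1 to compound 3 (0.22 log units; within the scatter) for the same position. Together with the earlier step, this shows that a rearrangement of the fluoro and methyl groups, and not only the addition of a fluoro group, leaves all three compounds level within the scatter. As far as these compounds go, whether an amine or a carboxylic acid on this phenyl ring would shift the number beyond the scatter remains open. Nothing available explains this result.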